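Swapping 4-methylpiperazin-1-yl for 3-methylphenyl on the Shared Core

This account rests on a few compounds, and the source may have more. Where it says the series, first, only, none or still open, it means among the compounds named here.

Compound 2 `CN1CCN(c2ccc(NCc3ccccc3O)cc2)CC1` shares its core with compound 1 `Oc1cc(I)ccc1CNc1ccc(C2CCCCC2)cc1` and compound 3 `CCOc1ccc(-c2ccc(NCc3ccccc3O)cc2)cc1`. In a functional assay on Jurkat cells (Homo sapiens) for activation, with a stated time of 24 h (a higher number here means that more compound is needed for the effect, a lower number that less compound is needed), compound 2 is reported as "not active" (no number reported), so no number stands behind it. Compound 1 likewise comes out as "not active" (no number reported) in this assay. Compound 3, by contrast, gives 520 nM in this assay. Compound 2 therefore stands among the two compounds without a number, and compound 3 alone supplies a measured half-maximal effective concentration in this set.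

Compound 4 `Cc1cccc(-c2ccc(NCc3ccccc3O)cc2)c1` has not been measured. It differs from compound 2 in one place: 3-methylphenyl in place of 4-methylpiperazin-1-yl on an aromatic carbon. Among the measured compounds shown here, no measured pair shows this change directly. Because compound 3, which also carries a six-membered aromatic ring of carbon only on the core, gives 520 nM, the step from compound 2 to compound 4 in this assay is expected to move toward a lower number, a number appearing where compound 2 has none. For compound 4 the expected value in this assay is 900 nM, with a range from 200 nM to 5000 nM.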

Compound 4, half-maximal effective concentration: 9190 nM
The estimate for compound 4 lay 10-fold (1.01 log units) below the measured number; the measured number lies above the stated range.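

Among the compounds shown here, compound 2 carries no number in this assay, and no step to compound 4 can be read from it. The compounds shown leave open how far 3-methylphenyl in place of 4-methylpiperazin-1-yl moves the number on this core. Nothing shown here offers an explanation for the result.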